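The compounds below may be only part of what the source reports. "The series", "measured", "known", "first", "only" and "open" are said of these compounds alone.

Measured in an ADME assay on Vero cells (Chlorocebus sabaeus) for cytotoxicity, read by resazurin assay, with a stated time of 72 h; on this read-out higher numbers stand for weaker inhibition and lower numbers for stronger inhibition:
- compound 1 `O=C(CCN1CCN(c2ccc(C(F)(F)F)cc2)CC1)c1ccccc1`: 15700 nM
- compound 2 `O=C(CCN1CCN(c2ccc(C(F)(F)F)cc2)CC1)c1ccc(F)c(F)c1`: 14000 nM

Compound 2, at 14000 nM, stands level with compound 1, at 15700 nM, as the two values lie within the scatter of each other. Compound 3 `O=C(CCN1CCN(c2ccc(C(F)(F)F)cc2)CC1)c1ccc(C(F)(F)F)cc1` keeps the shared core and changes one group: 4-(trifluoromethyl)phenyl in place of 3,4-difluorophenyl on a carbonyl carbon. In words, 4-(trifluoromethyl)phenyl stands in place of 3,4-difluorophenyl on a carbonyl carbon.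

For the measured compounds named here, one measured step bears on this change, as it falls at the same place: a 1.1-fold lower number from compound 1 to compound 2 (0.05 log units; within the scatter). That step stays within the scatter. Neither measured compound carries the 4-(trifluoromethyl)phenyl group, so the data give no direct reading for it, and a single step is thin support. On that evidence, no step beyond the scatter is expected in this assay, and no direction is firmly indicated. The expected change is a 1.2-fold lower number from compound 2 to compound 3 (0.07 log units; within the scatter). For compound 3 the estimated value is 12000 nM, with an expected range from 6000 nM to 24000 nM.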

Compound 3, half-maximal inhibitory concentration: 49200 nM
Compound 3: the middle estimate sits 4.1-fold (0.61 log units) below what was measured; the whole stated range lies below it.
By their numbers in this assay, from the lowest: compounds 2 and 1 (each within the scatter of the next); then compound 3.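

In this assay, the group on the carbonyl carbon proves able to move the number: 4-(trifluoromethyl)phenyl in place of 3,4-difluorophenyl gives a 3.5-fold higher number from compound 2 to compound 3 (0.55 log units; beyond the scatter), towards weaker inhibition, a shift the earlier pair of compounds, level within the scatter, gave no sign of. Against the unsubstituted phenyl of compound 1, trifluoromethyl in place of hydrogen on an aromatic carbon gives a 3.1-fold higher number from compound 1 to compound 3 (0.50 log units; beyond the scatter), so compound 3 stands apart from both earlier compounds, while the two fluorine atoms of compound 2 left the number level with that of compound 1. No measurement at hand speaks to what lies behind this shift.

With a single trifluoromethyl example, the compounds shown do not tell whether the shift belongs to that group alone or would also appear with a chlorine, a methoxy group, a nitrile or a carboxylic acid on the same aromatic ring. They also leave open whether the step holds when the saturated chain on the carbonyl carbon is longer.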